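This account rests on a few compounds, and the source may have more. Where it says the series, first, only, none or still open, it means among the compounds named here.

Measured compounds:
compound 1 `c1ccc2c(-c3cn4ccnc4c(-c4ccc5ncn(C6CCCCC6)c5c4)n3)cccc2c1`, in a functional assay on MOLT-4 cells (Homo sapiens) for inhibition, read by sulforhodamine B assay, with a stated time of 48 h, tested at 10 uM (a higher number here means more inhibition at the concentration tested (going by the name of the read-out), a lower number less inhibition), compound 1 gives 44.7%
compound 2 `c1ccc(Cn2cnc3ccc(-c4nc(-c5cccc6ccccc56)cn5ccnc45)cc32)cc1`, in this assay compound 2 gives 22.3%
compound 3 `c1cn2cc(-c3ccc4c(c3)ncn4C3CCCCC3)nc(-c3ccc4ncn(C5CCCCC5)c4c3)c2n1`, in this assay compound 3 gives 56.9%

Compound 1 and compound 2 differ in one place: benzyl in place of cyclohexyl on an aromatic nitrogen. That change made a step of a number 22.4 percentage points lower from compound 1 to compound 2 (beyond the scatter), a modest drop beyond the scatter. Compound 3 stands highest of the three in this assay; the difference between the core of compound 3 and the core of compound 1 is not broken down here.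

Compound 4 `c1ccc(Cn2cnc3ccc(-c4nc(-c5ccc6c(c5)ncn6C5CCCCC5)cn5ccnc45)cc32)cc1` is not yet measured. It differs from compound 3 in the same way: benzyl in place of cyclohexyl on an aromatic nitrogen. The place is the same as for the earlier pair, so this is the same change made on the core of compound 3 instead of the core of compound 1.

Given the step from compound 1 to compound 2 of a number 22.4 percentage points lower from compound 1 to compound 2 (beyond the scatter), the step from compound 3 to compound 4 is expected to be of similar size, about a number 21.9 percentage points lower from compound 3 to compound 4 (beyond the scatter). The estimate rests on a single precedent, so the range is wide. In this assay compound 4 is thus estimated at 35%, between 20% and 50%.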

Compound 4, a percentage reported as inhibition, at one concentration (the size of the read-out at that concentration, not a potency): 95.6%
The estimate for compound 4 lay 60.6 percentage points below the measured number; measured number above the stated range.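

Benzyl in place of cyclohexyl on an aromatic nitrogen gives a number 38.7 percentage points higher from compound 3 to compound 4 (beyond the scatter) in this assay on the core of compound 3. The change therefore does not carry from one core to another in this series with a fixed direction or size, as the two steps set together show: the same change on two cores in this assay, a number 22.4 percentage points lower (beyond the scatter) from compound 1 to compound 2 and a number 38.7 percentage points higher (beyond the scatter) from compound 3 to compound 4, 61.1 percentage points apart, beyond the scatter of two such steps.
Among the compounds shown here, with only two pairs, this shows that the outcome of the change depended on the core in these compounds, but it does not show why, nor predict the outcome on any further core.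

The compounds shown leave open whether the reversal is particular to benzyl or would also appear with other groups on that nitrogen, such as a longer alkyl chain or a chain ending in an amine. Also open, going by these compounds, is whether the high reading for compound 4 at a single concentration would hold as a potency across a range of concentrations or in other cell lines.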